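The source may report more compounds than this note shows. Statements on the series, on what has been measured and on what is new or still open speak of the compounds shown alone.

Measured in a functional assay with Rattus norvegicus as the target; on this read-out lower numbers stand for an effect already at smaller amounts and higher numbers for an effect only at larger amounts of compound:

Compound 1 `CC[C@@H](/N=C(\S)NCc1ccc(C(C)(C)C)cc1)c1ccc(NS(C)(=O)=O)cc1`: > 100000 nM (a limit, not a number)
Compound 2 `CC(C)C(/N=C(\S)NCc1ccc(C(C)(C)C)cc1)c1ccc(NS(C)(=O)=O)cc1`: > 100000 nM (a limit, not a number)

Neither compound gave a true half-maximal value, and both stand at the limit of > 100000 nM in this assay, at which 2 of the 2 values shown sit. Compound 2 therefore has no exact position on the scale, only its limit of > 100000 nM.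

Compound 3 `CCCC(/N=C(\S)NCc1ccc(C(C)(C)C)cc1)c1ccc(NS(C)(=O)=O)cc1` has not yet been measured. It keeps the rest of compound 2 and carries one change: propyl in place of isopropyl on a saturated chain carbon bound to an aromatic carbon and a double-bonded nitrogen. Put simply, the two compounds have the same atoms, joined differently.

Going by the values given here, no measured pair gives the size of such a change, so any forecast is rough. Compound 2, at > 100000 nM, is the closest guide, and it points to no step beyond the scatter in this assay. Another limit is the most likely report, although a measurable number remains possible. The estimated change is a number no higher from compound 2 to compound 3 (the limit leaves the size open). The expected value for compound 3 is 100000 nM, with an estimated range from 30000 nM to 200000 nM.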

Compound 3, half-maximal effective concentration: > 100000 nM
Compound 3 gave a limit, no number; the forecaster's own chance of this, stated with the estimate: 80%; the middle value lies on the limit itself.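

Going by these compounds alone, compound 2 and compound 3 each give only a limit rather than a number, so no step between them can be read for propyl in place of isopropyl, because all the values shown sit at one limit: the limit of > 100000 nM in this assay, at which 3 of the 3 values shown sit. The compounds shown leave open whether this change alters the effect in this assay at all.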